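Dimethoxyphenyl for Dimethylphenyl on a Second Core

The compounds below may be only part of what the source reports. "The series", "measured", "known", "first", "only" and "open" are said of these compounds alone.

Measured so far in a functional assay on DU-145 cells (Homo sapiens) for antiproliferative activity, read by MTT assay, with a stated time of 24 h; a lower number here means a stronger inhibitor, a higher number a weaker inhibitor:
Compound 1, `COc1ccc(-c2cc(/C=C/C(=O)c3ccc(C)c(C)c3)nc3cc(-c4ccccc4)nn23)cc1OC`: compound 1 gives 12100 nM.
Compound 2, `COc1ccc(C(=O)/C=C/c2cc(-c3ccc(OC)c(OC)c3)n3nc(-c4ccccc4)cc3n2)cc1OC`: compound 2 gives 7200 nM.
Compound 3, `COc1cc(-c2cc(/C=C/C(=O)c3ccc(C)c(C)c3)nc3cc(-c4ccccc4)nn23)cc(OC)c1OC`: compound 3 gives 15400 nM.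

Compound 2 differs from compound 1 by 3,4-dimethoxyphenyl in place of 3,4-dimethylphenyl on a carbonyl carbon, and in this assay this gave a 1.7-fold lower number from compound 1 to compound 2 (0.23 log units; within the scatter). Compound 3 differs from compound 1 by methoxy in place of hydrogen on an aromatic carbon, with a 1.3-fold higher number from compound 1 to compound 3 (0.10 log units; within the scatter). Compound 4, `COc1ccc(C(=O)/C=C/c2cc(-c3cc(OC)c(OC)c(OC)c3)n3nc(-c4ccccc4)cc3n2)cc1OC`, is not yet measured; it differs from compound 3 by 3,4-dimethoxyphenyl in place of 3,4-dimethylphenyl on a carbonyl carbon, which is the same change as that from compound 1 to compound 2, at the same place. On that basis the expected step is a 1.7-fold lower number from compound 3 to compound 4 (0.23 log units; within the scatter), resting on a 1.7-fold lower number from compound 1 to compound 2 (0.23 log units; within the scatter). Compound 4 is therefore estimated at 9000 nM in this assay, with a likely range from 4000 nM to 20000 nM.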

Compound 4, half-maximal inhibitory concentration: 29900 nM
Compound 4: middle estimate off by 3.3-fold (0.52 log units), on the low side, and the stated range ends below it.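

In this assay the change to 3,4-dimethoxyphenyl on the carbonyl carbon gave a 1.9-fold higher number from compound 3 to compound 4 (0.29 log units; within the scatter) and did not repeat its earlier step: the same change on two cores in this assay, a 1.7-fold lower number (0.23 log units; within the scatter) from compound 1 to compound 2 and a 1.9-fold higher number (0.29 log units; within the scatter) from compound 3 to compound 4, 3.3-fold (0.51 log units) apart, beyond the scatter of two such steps.

The added methoxy gave a 4.2-fold higher number from compound 2 to compound 4 (0.62 log units; beyond the scatter) and likewise differed from its earlier step: the same change on two cores in this assay, a 1.3-fold higher number (0.10 log units; within the scatter) from compound 1 to compound 3 and a 4.2-fold higher number (0.62 log units; beyond the scatter) from compound 2 to compound 4, 3.3-fold (0.51 log units) apart, beyond the scatter of two such steps.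

These four compounds therefore show that neither change carried over unaltered from one core to the other, but they form only one such set and do not show why the two changes fail to add up.

Going by these compounds, it remains open whether this holds on other cores, and whether an amine or a carboxylic acid in place of the methoxy groups on the phenyl ring at the carbonyl carbon would carry over any better.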